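A hydroxy group becomes an acetoxy group

The source may report more compounds than this note shows. Statements on the series, on what has been measured and on what is new or still open speak of the compounds shown alone.

Of the compounds shown here, three have been measured in an ADME assay on HepG2 cells (Homo sapiens) for cytotoxicity, read by CellTiter-Glo, with a stated time of 72 h; a lower number here means that less compound is needed, a higher number that more compound is needed for the effect. Compound 1 `CCOC(=O)CNC(=O)[C@H](CS[C@H]1[C@@H]2C(=O)/C(C)=C\C3=C[C@H](C)C[C@@]34O[C@]2(CC1(C)C)[C@@H](C)C4=O)NC(=O)CC[C@H](N)C(=O)O` gives 26000 nM, compound 2 `CC1=C2CC(C)(C)/C=C/C/C(C)=C\C3=C[C@H](C)C[C@]3(O2)C1=O` gives 26000 nM, and compound 3 `CC1=C2CC(C)(C)/C=C/[C@H](O)/C(C)=C\C3=C[C@H](C)C[C@]3(O2)C1=O` gives 18700 nM. Compound 3 therefore lies within the scatter of both others, and the three cannot be ranked on these numbers.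

Compound 4 `CC(=O)O[C@H]1/C=C/C(C)(C)CC2=C(C)C(=O)[C@]3(C[C@@H](C)C=C3/C=C\1C)O2` differs from compound 3 by acetyl in place of hydrogen on an oxygen on a saturated carbon, which reads as hydroxy to acetoxy. Going by the values given here, only one measured step bears on this change. It is a 1.4-fold lower number from compound 2 to compound 3 (0.14 log units; within the scatter), for hydroxy in place of hydrogen on a saturated ring carbon, and it stays within the scatter. Among the compounds with values here, no measured compound carries an acetyl group on that oxygen, so this evidence is indirect. Within the data shown here, with so small a step as the only guide, no shift beyond the scatter is expected in either direction. The estimated step is a 1.1-fold higher number from compound 3 to compound 4 (0.03 log units; within the scatter). Compound 4 is expected at 20000 nM, with an estimated range from 9000 nM to 40000 nM.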

Compound 4, half-maximal effective concentration: 26000 nM
For compound 4 the middle estimate is 1.3-fold (0.11 log units) below the measured one; the range from low to high includes it.
By their numbers in this assay, from the lowest: compounds 3, 1, 2 and 4 (each within the scatter of the next).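

In this assay, going by these compounds alone, the change from hydroxy to acetoxy gives a 1.4-fold higher number from compound 3 to compound 4 (0.14 log units; within the scatter) and so provides the first direct reading of a group on this oxygen. Acetoxy in place of hydrogen on the saturated ring carbon gives no change at the digits printed from compound 2 to compound 4 (within the scatter) and thus shows that neither hydroxy nor acetoxy at this position separates from hydrogen on these numbers, with the added acetyl leaving the result within the scatter. The data offer no measured reason for these readings.

On these data alone, it remains open whether an amine or a carboxylic acid at this position, or a longer acyl chain on the oxygen, would give a step beyond the scatter. The compounds shown also leave open whether any group here can move the number at all.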